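From carbamoyl to benzamido in a growth-inhibition series

The source may hold more compounds than are shown below. What is called first, only, known or untested is meant among the compounds shown, and "the series" means these compounds.

Compound 1 `COc1ccc([C@@H]2C/C(=N/OCc3cn(-c4ccc(O)cc4)nn3)c3cc(CC=C(C)C)c(OC)cc3O2)cc1`: 63%
Compound 2 `COc1ccc([C@@H]2C/C(=N/OCc3cn(-c4ccc(C#N)cc4)nn3)c3cc(CC=C(C)C)c(OC)cc3O2)cc1`: 40%
Compound 3 `COc1ccc([C@@H]2C/C(=N/OCc3cn(-c4ccc(C(N)=O)cc4)nn3)c3cc(CC=C(C)C)c(OC)cc3O2)cc1`: 100%

In a functional assay on MCF7 cells (Homo sapiens) for inhibition, read by sulforhodamine B assay, with a stated time of 48 h, tested at 50 uM (on this read-out lower numbers stand for less inhibition of growth and higher numbers for more inhibition of growth at the one concentration tested), compound 3 stands highest of the three at 100%, and both other compounds lie beyond the scatter below it. Compound 4 `COc1ccc([C@@H]2C/C(=N/OCc3cn(-c4ccc(NC(=O)c5ccccc5)cc4)nn3)c3cc(CC=C(C)C)c(OC)cc3O2)cc1` differs from it as follows: benzamido in place of carbamoyl on an aromatic carbon. In short, benzamido stands in place of carbamoyl on an aromatic carbon. All three measured steps change this same substituent: a number 23 percentage points lower from compound 1 to compound 2 (beyond the scatter), a number 37 percentage points higher from compound 1 to compound 3 (beyond the scatter) and a number 60 percentage points higher from compound 2 to compound 3 (beyond the scatter). Going by the values given here, the read-out thus moves widely with this group, but no measured compound carries benzamido, so the direction remains uncertain. With compound 3 at the top, a large downward step is expected: a number 35 percentage points lower from compound 3 to compound 4 (beyond the scatter). For compound 4 the estimated value is 65%, with an expected range of 35% to 95%.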

Compound 4, percent growth inhibition at one concentration: 4%
Compound 4: middle estimate off by 61 percentage points, on the high side, and the stated range ends above it.
By their numbers in this assay, from the lowest: compound 4; then compound 2; then compound 1; then compound 3.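

In this assay, benzamido, with its added six-membered aromatic ring of carbon only, gives the lowest number of the four compounds on this aromatic carbon (a number 96 percentage points lower from compound 3 to compound 4 (beyond the scatter); a number 36 percentage points lower from compound 2 to compound 4 (beyond the scatter); a number 59 percentage points lower from compound 1 to compound 4 (beyond the scatter)). Carbamoyl and benzamido both carry a carbonyl and an amide hydrogen, yet they mark the two ends of the series, so sharing these features does not keep the number high. Nothing available here bears on the cause of this fall. From the compounds shown here alone, whether an acetamido group or a carboxylic acid here would stay near compound 3 or fall toward compound 4 remains open.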